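The source may report more compounds than this note shows. Statements on the series, on what has been measured and on what is new or still open speak of the compounds shown alone.

Measured so far:
compound 1, `COc1ccc(C(=O)/C=C/c2ccc(F)cc2)c2c1C=CC(C)(C)O2`: > 10000 nM
compound 2, `COc1ccc(C(=O)/C=C/c2ccc(Br)cc2)c2c1C=CC(C)(C)O2`: > 10000 nM
compound 3, `COc1ccc(C(=O)/C=C/c2ccc([N+](=O)[O-])cc2)c2c1C=CC(C)(C)O2`: 2610 nM

In a functional assay on HepG2 cells (Homo sapiens) for antiproliferative activity, read by MTT assay, with a stated time of 24 h (on this read-out lower numbers stand for stronger inhibition and higher numbers for weaker inhibition), compound 1 gives > 10000 nM, which is a limit of the assay, not a number. Compound 2 likewise gives > 10000 nM, also a limit. Because of the limit of > 10000 nM in this assay, at which 2 of the 3 values shown sit, the step that the two limits leave unreadable from compound 1 to compound 2 cannot be read. Going by the values given here, compound 3 gives 2610 nM, the only real number here, reached through an at least 3.8-fold lower number from compound 1 to compound 3 (0.58 log units; beyond the scatter) and an at least 3.8-fold lower number from compound 2 to compound 3 (0.58 log units; beyond the scatter).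

Compound 4, `COc1ccc(C(=O)/C=C/c2cccc([N+](=O)[O-])c2)c2c1C=CC(C)(C)O2`, differs from compound 3 by 3-nitrophenyl in place of 4-nitrophenyl on a double-bonded chain carbon bound to a double-bonded chain carbon. Among the compounds with values here, none of the measured steps moves a group to another ring carbon; all swap the group on the same carbon, so they do not bear directly on this change. The expectation is therefore a step of a 1.5-fold higher number from compound 3 to compound 4 (0.19 log units; within the scatter), with compound 4 estimated at 4000 nM in this assay, within a range from 1500 nM to 12000 nM.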

Compound 4, half-maximal inhibitory concentration: 2830 nM
Compound 4: middle estimate off by 1.4-fold (0.15 log units), on the high side, within the range that was stated.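

Placing the nitro group as 3-nitrophenyl rather than 4-nitrophenyl makes no readable difference in this assay: the result is a 1.1-fold higher number from compound 3 to compound 4 (0.04 log units; within the scatter). The advantage over the halogen compounds therefore holds for both nitro placements, with an at least 3.5-fold lower number from compound 2 to compound 4 (0.54 log units; beyond the scatter) and an at least 3.5-fold lower number from compound 1 to compound 4 (0.54 log units; beyond the scatter). The full size of these two steps cannot be read because the halogen compounds sit at a limit: the limit of > 10000 nM in this assay, at which 2 of the 4 values shown sit.

Still open, from the compounds shown here alone, is whether an amine or a carboxylic acid in place of the nitro group would give a value like those of compound 3 and compound 4.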